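Halogen swap on the anilide ring of a dimethoxy indanone core

This account rests on a few compounds, and the source may have more. Where it says the series, first, only, none or still open, it means among the compounds named here.

The measured compounds are:
compound 1, `COc1cc2c(cc1OC)C(=O)C(C(=O)Nc1ccc(Cl)cc1)C2`, 56.8 ug/mL;
compound 2, `COc1cc2c(cc1OC)C(=O)C(C(=O)Nc1ccc(Br)cc1)C2`, 72.1 ug/mL;
compound 3, `COc1cc2c(cc1OC)C(=O)C(C(=O)Nc1cccc(Cl)c1)C2`, 76.3 ug/mL.

All three were run in a physicochemical assay, with a stated time of 30 min; a higher number here means a weaker inhibitor, a lower number a stronger inhibitor. Compound 1 and compound 2 share a core and differ by bromo in place of chloro on an aromatic carbon. Compound 1 and compound 3 share the same atoms joined differently, the difference being (3-chlorophenyl in place of 4-chlorophenyl on an amide-type nitrogen). In this assay the step of a 1.3-fold higher number from compound 1 to compound 2 (0.10 log units; within the scatter); the step of a 1.3-fold higher number from compound 1 to compound 3 (0.13 log units; within the scatter); and the step of a 1.1-fold higher number from compound 2 to compound 3 (0.02 log units; within the scatter). None of these steps reaches beyond the scatter, so the three numbers are best read as lying together.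

Compound 4, `COc1cc2c(cc1OC)C(=O)C(C(=O)Nc1cccc(Br)c1)C2`, has not yet been measured in this assay. It differs from compound 3 by bromo in place of chloro on an aromatic carbon. This is the same kind of change as that from compound 1 to compound 2, though not the same: in compound 1 the halogen sits para to a large group, in compound 3 meta to a large group. Among the compounds with values here, the one measured example of this kind of change, a 1.3-fold higher number from compound 1 to compound 2 (0.10 log units; within the scatter), was small and within the scatter. On that basis the step from compound 3 to compound 4 is expected to be of similar size, a 1.2-fold higher number from compound 3 to compound 4 (0.10 log units; within the scatter). Compound 4 is accordingly estimated to give 95 ug/mL in this assay, with a likely range from 55 ug/mL to 165 ug/mL.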

Compound 4, half-maximal inhibitory concentration: 58.9 ug/mL
For compound 4 the middle estimate is 1.6-fold (0.21 log units) above the measured one; low and high end bracket the measured number.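

In this assay the change of chloro to bromo on an aromatic carbon can now be read in two settings, once on the 4-chlorophenyl amide, with a 1.3-fold higher number from compound 1 to compound 2 (0.10 log units; within the scatter), and once on the 3-chlorophenyl amide, with a 1.3-fold lower number from compound 3 to compound 4 (0.11 log units; within the scatter). Both steps stay within the scatter, as do the two other new steps, a 1.2-fold lower number from compound 2 to compound 4 (0.09 log units; within the scatter) and a 1.0-fold higher number from compound 1 to compound 4 (0.02 log units; within the scatter), so all four compounds lie together and the swap of these two halogens leaves the number effectively unmoved in both settings. The printed signs of the two swap steps differ, but this does not show that the change acts in opposite ways in the two settings, and two small steps do not show that it would stay this small on any other core; no measurement bearing on the reason for these numbers is given.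

The compounds shown leave open whether anything on this aromatic ring moves the number beyond the scatter, as they carry only chloro and bromo there. A group of another kind in that place, such as an amine, a carboxylic acid or a nitrile, could answer that, and so could a change to the shared core itself.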